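The source may report more compounds than this note shows. Statements on the series, on what has been measured and on what is new or still open speak of the compounds shown alone.

Measured so far in an ADME assay on NIH3T3 cells (Mus musculus) for cytotoxicity, read by MTT assay, with a stated time of 72 h; a higher number here means a weaker inhibitor, a lower number a stronger inhibitor:
- compound 1 `Cc1cc(/C=C/c2ccc(O)cc2)[nH]n1` gives 59200 nM
- compound 2 `COc1ccc(/C=C/c2cc(C)n[nH]2)cc1` gives 19900 nM
- compound 3 `COc1ccc(/C=C/C(=O)CC(C)=O)cc1` gives 48200 nM

Compound 4 `CC(=O)CC(=O)/C=C/c1ccc(O)cc1` has not yet been measured. It differs from compound 3 by hydrogen in place of methyl on an oxygen on an aromatic ring. The same change, (hydrogen in place of methyl on an oxygen on an aromatic ring), links the two measured compounds, where it gave a 3.0-fold higher number from compound 2 to compound 1 (0.47 log units; beyond the scatter). The place of the change is described in identical words for both pairs, so this is the same change, but the shared core of compound 3 and compound 2 differs in a way that is not broken down here. In this assay a step of similar direction and size is expected for compound 4, a 2.5-fold higher number from compound 3 to compound 4 (0.40 log units; beyond the scatter), because the same change gave a 3.0-fold higher number from compound 2 to compound 1 (0.47 log units; beyond the scatter) on the other core. Compound 4 is therefore estimated at 120000 nM, with the likely span running from 50000 nM to 300000 nM.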

Compound 4, half-maximal inhibitory concentration: 18900 nM
Compound 4: the middle estimate sits 6.3-fold (0.80 log units) above what was measured; measured number outside the range, below it.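

In this assay, replacing methoxy with hydroxy gives a 2.6-fold lower number from compound 3 to compound 4 (0.41 log units; beyond the scatter). Set beside the earlier step, the same change moves the number in opposite directions on the two cores: the same change on two cores in this assay, a 3.0-fold higher number (0.47 log units; beyond the scatter) from compound 2 to compound 1 and a 2.6-fold lower number (0.41 log units; beyond the scatter) from compound 3 to compound 4, 7.6-fold (0.88 log units) apart, beyond the scatter of two such steps

This shows that, within these two pairs, the result of the change on one core does not predict its result on the other, so it cannot simply be carried across. It does not show which difference between the cores lies behind this, and two pairs cannot establish a general rule for the series.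

The compounds shown leave open whether a longer chain on that oxygen, such as ethyl, would also behave differently on the two cores. The same question stands for an amine in place of the hydroxy.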